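The source may hold more compounds than are shown below. What is called first, only, known or untested is meant among the compounds shown, and "the series" means these compounds.

The account starts from two measured compounds. Compound 1 `COc1ccc(-c2nc(SCC3C[C@](C)(O)CC(=O)O3)[nH]c2-c2ccc(OC)cc2)cc1` was tested in an assay on microsomes from liver for inhibition of sterol O-acyltransferase 1 (Rattus norvegicus) (a lower number here means a stronger inhibitor, a higher number a weaker inhibitor), where compound 1 gives 420 nM. Compound 2 `CO[C@H]1C[C@H](O)C[C@@H](CSc2nc(-c3ccccc3)c(-c3ccccc3)[nH]2)O1` gives 90 nM in this assay, the lower of the two numbers, and the gap to compound 1 is beyond the usual scatter. Compound 3 `CCOC(CCSc1nc(-c2ccccc2)c(-c2ccccc2)[nH]1)OCC` has not yet been tested. It differs from compound 2 as follows: a group of 8 heavy atoms (6 carbon, 2 oxygen; no ring) in place of a group of 9 heavy atoms (6 carbon, 3 oxygen; one six-membered non-aromatic ring with 1 hetero atom), on a saturated chain carbon bound to a sulfur. The six-membered non-aromatic ring of compound 2 leaves and an open 2,2-diethoxyethyl group enters on the saturated chain carbon bound to the sulfur. Within the data shown here, no measured pair shows a change of this kind, so the direction of the step is uncertain, but the loss of the ring is expected to cost potency, and a step from compound 2 to compound 3 of a 4.4-fold higher number from compound 2 to compound 3 (0.65 log units; beyond the scatter) is estimated. For compound 3 the expected value in this assay is 400 nM, with a range from 120 nM to 1500 nM.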

Compound 3, half-maximal inhibitory concentration: 69 nM
Estimate against measurement, compound 3: 5.8-fold (0.76 log units) above, and the stated range ends above it.
By their numbers in this assay, from the lowest: compounds 3 and 2 (each within the scatter of the next); then compound 1.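

On the saturated chain carbon bound to a sulfur, the six-membered non-aromatic ring of compound 2 gives way to an open 2,2-diethoxyethyl group with a 1.3-fold lower number from compound 2 to compound 3 (0.12 log units; within the scatter) in this assay. This position therefore tolerates a group with no ring and 0 hydrogen-bond donors, so neither feature of the group that leaves is needed for a number of this size in this assay. The compounds shown offer no further evidence that would explain this result.

As far as these compounds go, it remains open whether a simple longer alkyl chain or an amine in the same place would keep the number in this range. From the compounds shown here alone, it also remains open whether the 2,2-diethoxyethyl group would behave the same way on the core of compound 1.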